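A few compounds are considered here, and "the series" means these few. Any claim that something is new, unique, unknown or untested is made for them only; others in the source may bear on it.

Compound 1 `Cc1nc(-c2ccccc2)c(C(=O)N2CCN(c3cccc(C(F)(F)F)c3)CC2)o1` is the starting point of this account. In a functional assay on HL-60 cells (Homo sapiens) for inhibition, read by MTT assay, with a stated time of 72 h (a higher number here means a weaker inhibitor, a lower number a stronger inhibitor), compound 1 gives 153 nM. Compound 3 `CCC[C@H](Nc1nc(-c2ccc(NC(=O)NCC)c(OC)c2)ncc1C)c1cccnc1`, a compound of a different build, gives 112 nM in the same test, and the two numbers lie within the usual scatter of each other, so neither can be called the stronger of the pair. Compound 2 `Cc1ccc(C)c(N2CCN(C(=O)c3oc(C)nc3-c3ccc(Cl)cc3)CC2)c1` was reported as "not active" (no number reported) in this assay, with no number attached; it differs from compound 1 in more than one place, so the two values alone say nothing about any single change.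

Compound 4 `Cc1nc(-c2ccccc2)c(C(=O)N2CCN(c3cc(Cl)cc(Cl)c3)CC2)o1` has not yet been measured. It differs from compound 1 in one place: 3,5-dichlorophenyl in place of 3-(trifluoromethyl)phenyl on an amine nitrogen in a ring. Within the data shown here, no pair of measured compounds isolates a change of this kind, so there is no measured step to lean on. The expectation is a modest move, if any, in this assay, with the number for compound 4 estimated at 250 nM (from 80 nM to 900 nM), corresponding to an expected step of a 1.6-fold higher number from compound 1 to compound 4 (0.21 log units; within the scatter).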

Compound 4, half-maximal inhibitory concentration: 41.8 nM
Compound 4: middle estimate off by 6.0-fold (0.78 log units), on the high side; the whole stated range lies above it.
By their numbers in this assay, from the lowest: compound 4; then compounds 3 and 1 (each within the scatter of the next).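

Placing 3,5-dichlorophenyl in place of 3-(trifluoromethyl)phenyl on the amine nitrogen in the ring gives a 3.7-fold lower number from compound 1 to compound 4 (0.56 log units; beyond the scatter) in this assay. Among these compounds, this is the first single change that can be read here, and it shows that the number in this assay responds to the group at this position by more than the scatter. The step comes with no difference between the two groups in hydrogen-bond donors, hydrogen-bond acceptors or net charge, and no measurement bears on why the number moves.

The compounds shown leave open whether bromine or a nitrile on this phenyl ring would give a number like that of compound 4. They also leave open whether the same exchange would give a similar step with the rest of the molecule changed.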